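Dimethylamino for methyl: an expected step in aortic inhibition

The source may report more compounds than this note shows. Statements on the series, on what has been measured and on what is new or still open speak of the compounds shown alone.

Measured compounds:
compound 1, `COc1nc(-c2cc3ccccc3o2)cc(-c2ccc(Cl)cc2Cl)c1C#N`, 322000 nM
compound 2, `COc1nc(-c2cc3ccccc3o2)cc(-c2ccc(C)cc2)c1C#N`, 266000 nM

Of the compounds shown here, two have been measured in a functional assay on aorta (strain Wistar) for inhibition, with Thoracic aorta (Rattus norvegicus) as the target; on this read-out lower numbers stand for stronger inhibition and higher numbers for weaker inhibition. Compound 1 gives 322000 nM and compound 2 gives 266000 nM; compound 2 sits together with compound 1, since a 1.2-fold lower number from compound 1 to compound 2 (0.08 log units; within the scatter) lies within the scatter, so neither compound is set apart from the other on the numbers shown.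

Compound 3, `COc1nc(-c2cc3ccccc3o2)cc(-c2ccc(N(C)C)cc2)c1C#N`, is not yet measured. It differs from compound 2 by dimethylamino in place of methyl on an aromatic carbon. Within the data shown here, no measured step touches this exchange directly: the only step on record, the one from compound 1 to compound 2, trades one aryl group for another and stays within the scatter. Nothing in the two numbers therefore points to a move in either direction, and for compound 3 a change no larger than the scatter is expected, with a 1.0-fold lower number from compound 2 to compound 3 (0.01 log units; within the scatter) as the estimated step. On that basis compound 3 is expected to give about 260000 nM in this assay, with a range from 100000 nM to 650000 nM.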

Compound 3, half-maximal inhibitory concentration: 278000 nM
Compound 3: the middle estimate sits 1.1-fold (0.03 log units) below what was measured; measured number inside the range.
By their numbers in this assay, from the lowest: compounds 2, 3 and 1 (each within the scatter of the next).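

In this assay, among these compounds, the exchange of methyl for dimethylamino on an aromatic carbon, para to a large group, gives a 1.0-fold higher number from compound 2 to compound 3 (0.02 log units; within the scatter) and so brings the first nitrogen-bearing group to this place without separating the two compounds. The exchange of 2,4-dichlorophenyl for 4-(dimethylamino)phenyl gives a 1.2-fold lower number from compound 1 to compound 3 (0.06 log units; within the scatter) and likewise stays inside the scatter, so the three aryl groups shown, with chlorine, carbon or nitrogen on the ring, cannot be told apart on these numbers. No evidence is at hand that could account for this flat result.

The compounds shown leave open whether any group at this place can shift the number beyond the scatter, for instance a carboxylic acid, a primary amine or a longer chain such as butyl in place of the methyl of compound 2. They also leave open whether the flat result is confined to this aryl group, since the methoxy, the nitrile and the rest of the shared core stay the same in compound 1, compound 2 and compound 3.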